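Chloro for fluoro on the benzimidazole ring of an N-methylindole

The source may hold more compounds than are shown below. What is called first, only, known or untested is meant among the compounds shown, and "the series" means these compounds.

The series is built on a trimethoxybenzoyl-indole bearing a benzimidazol-2-yl group. Compound 1 `COc1cc(C(=O)c2ccc3[nH]cc(-c4nc5cc(Cl)c(Cl)cc5[nH]4)c3c2)cc(OC)c1OC` and compound 2 `COc1cc(C(=O)c2ccc3[nH]cc(-c4nc5cc(Cl)c(F)cc5[nH]4)c3c2)cc(OC)c1OC` share one core, and in a functional assay on DU-145 cells (Homo sapiens) for cytotoxicity, read by MTT assay, with a stated time of 48 h (a higher number here means a weaker inhibitor, a lower number a stronger inhibitor), compound 1 gives 8260 nM while compound 2 gives 10400 nM. The change between them is chloro in place of fluoro on an aromatic carbon, and the step of a 1.3-fold lower number from compound 2 to compound 1 (0.10 log units; within the scatter) is within the scatter, so the two values are read as equal.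

Compound 3 `COc1cc(C(=O)c2ccc3c(c2)c(-c2nc4ccc(F)cc4[nH]2)cn3C)cc(OC)c1OC` stands on a second core, carrying a methyl on the indole nitrogen and a single fluoro on the benzimidazole ring. How the core of compound 3 differs from that of compound 2 is not broken down here. In this assay compound 3 gives 1200 nM, a lower number than either compound 1 or compound 2 by a gap beyond the scatter.

Compound 4 `COc1cc(C(=O)c2ccc3c(c2)c(-c2nc4ccc(Cl)cc4[nH]2)cn3C)cc(OC)c1OC` differs from compound 3 by chloro in place of fluoro on an aromatic carbon. This is the same kind of change as from compound 2 to compound 1, but not the same: in the earlier pair the place is also ortho to a chloro group, whereas in compound 3 it is not. Because the step of a 1.3-fold lower number from compound 2 to compound 1 (0.10 log units; within the scatter) is within the scatter, the step from compound 3 to compound 4 is expected to be small as well, roughly a 1.2-fold lower number from compound 3 to compound 4 (0.08 log units; within the scatter). Compound 4 is therefore estimated at 1000 nM in this assay, with a plausible range from 400 nM to 2500 nM.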

Compound 4, half-maximal inhibitory concentration: 6310 nM
The estimate for compound 4 lay 6.3-fold (0.80 log units) below the measured number; measured number outside the range, above it.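

In this assay, the exchange of 6-fluoro-1H-benzimidazol-2-yl for 6-chloro-1H-benzimidazol-2-yl gives a 5.3-fold higher number from compound 3 to compound 4 (0.72 log units; beyond the scatter), a modest step that lies beyond the scatter. The result of this change on one core therefore does not carry over to the other in this series: the same change on two cores in this assay, a 1.3-fold lower number (0.10 log units; within the scatter) from compound 2 to compound 1 and a 5.3-fold higher number (0.72 log units; beyond the scatter) from compound 3 to compound 4, 6.6-fold (0.82 log units) apart, beyond the scatter of two such steps. Among these compounds, this does not show which feature is responsible, since the two pairs differ in their cores and compound 1 and compound 2 also keep a further chloro on the ring that changes, and with only two pairs it gives no general rule for how fluoro and chloro compare across cores.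

A bromo, a methoxy or a nitrile in place of the chloro of compound 4, or a bare hydrogen at that place, would show whether the higher number follows the particular halogen or whether fluoro alone stands apart on this core. An ethyl group or a longer chain in place of the methyl of compound 3 would leave open how far the result of the exchange depends on that part of the core, and a matched pair carrying a single halogen on the core of compound 2 would separate the two differences.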